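A few compounds are considered here, and "the series" means these few. Any claim that something is new, unique, unknown or untested is made for them only; others in the source may bear on it.

Four compounds share a core in which a sulfonamide links a pyrimidinedione to an aniline that carries a triazole bearing an aryl group on one of its ring nitrogens. Compound 1 is `O=c1[nH]cc(S(=O)(=O)Nc2ccccc2-c2cn(-c3ccc(F)cc3)nn2)c(=O)[nH]1` and compound 2 is `O=c1[nH]cc(S(=O)(=O)Nc2ccccc2-c2cn(-c3ccccc3Cl)nn2)c(=O)[nH]1`. Compound 3 is `O=c1[nH]cc(S(=O)(=O)Nc2ccc(-c3cn(-c4ccc(F)cc4)nn3)cc2)c(=O)[nH]1`, and compound 4, not yet measured, is `O=c1[nH]cc(S(=O)(=O)Nc2ccc(-c3cn(-c4ccccc4Cl)nn3)cc2)c(=O)[nH]1`.

In a functional assay on HepG2 cells (Homo sapiens) for antiproliferative activity, read by MTT assay, with a stated time of 24 h (on this read-out lower numbers stand for stronger inhibition and higher numbers for weaker inhibition), compound 1 reaches only a limit of the assay, giving > 20000 nM. Compound 2 in this assay gives 2240 nM. The change from compound 1 to compound 2 is 2-chlorophenyl in place of 4-fluorophenyl on an aromatic nitrogen, and it produced an at least 8.9-fold lower number from compound 1 to compound 2 (0.95 log units; beyond the scatter). Compound 3 likewise gives only a limit in this assay, > 20000 nM. Two of the three measured values sit at the limit of > 20000 nM in this assay, at which 2 of the 3 values shown sit.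

Compound 3 and compound 1 are built from the same atoms joined differently; how the two cores differ is not broken down here. The change from compound 3 to compound 4 is 2-chlorophenyl in place of 4-fluorophenyl on an aromatic nitrogen, the same change as from compound 1 to compound 2.

Because the same change gave an at least 8.9-fold lower number from compound 1 to compound 2 (0.95 log units; beyond the scatter), compound 4 is expected to show a step of about an at least 3.3-fold lower number from compound 3 to compound 4 (0.52 log units; beyond the scatter) from compound 3, though the starting point for compound 3 is only a limit, so the size is uncertain. Compound 4 is therefore estimated at 6000 nM, between 1500 nM and 20000 nM.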

Compound 4, half-maximal inhibitory concentration: 2230 nM
Beside the measured number, compound 4's estimate is 2.7-fold (0.43 log units) above it; the measured number falls inside the stated range.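

In this assay, 2-chlorophenyl in place of 4-fluorophenyl gave an at least 8.9-fold lower number from compound 3 to compound 4 (0.95 log units; beyond the scatter), so the change that lowered the number on the core of compound 1 also lowered it on the core of compound 3: the same change on two cores in this assay, an at least 8.9-fold lower number (0.95 log units; beyond the scatter) from compound 1 to compound 2 and an at least 8.9-fold lower number (0.95 log units; beyond the scatter) from compound 3 to compound 4; the limit leaves it open whether they differ

Each step starts from a limit rather than a true number, so each gives only the smallest size the step could have, and the real sizes could match or could be quite different: the limit of > 20000 nM in this assay, at which 2 of the 4 values shown sit.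

This pair of steps therefore shows that the direction of the change carried from one core to the other, and that on both cores the step lies beyond the scatter; it does not show that the change is worth the same amount on each core, and two cores make no rule for any further core.

The compounds shown also leave open which part of the change matters, the kind of halogen or its place on the ring, as both differ at once between 4-fluorophenyl and 2-chlorophenyl. A 4-chlorophenyl or a 2-fluorophenyl group on the same nitrogen would pull these two apart, and a plain phenyl group would show what either halogen adds in this assay.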